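Swapping Bromo for Fluoro on the Shared Core

This account rests on a few compounds, and the source may have more. Where it says the series, first, only, none or still open, it means among the compounds named here.

Of the compounds shown here, three sharing one core have been tested in a functional assay on C6 cells (Rattus norvegicus) for cytotoxicity, read by MTT assay, with a stated time of 24 h, tested at 50 ug/mL; a higher number here means a weaker effect of the compound at the concentration tested, a lower number a stronger effect. Compound 1 `O=C(CSc1nnnn1-c1ccccc1)N/N=c1/scc(-c2ccc(Br)cc2)n1-c1ccccc1` gives 32%. Compound 2 `O=C(CSc1ncccn1)N/N=c1/scc(-c2ccc(Br)cc2)n1-c1ccccc1` gives 69%, the second highest of the three numbers; compound 3 `Cn1nnnc1SCC(=O)N/N=c1/scc(-c2ccc([N+](=O)[O-])cc2)n1-c1ccccc1` gives 69.2%, which sits within the scatter of compound 2, whereas compound 1 lies far below it. For the measured compounds named here, the only one-place step among the measured compounds is a number 37 percentage points higher from compound 1 to compound 2 (beyond the scatter), a change on the sulfur, not on the aromatic ring.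

Compound 4 `O=C(CSc1ncccn1)N/N=c1/scc(-c2ccc(F)cc2)n1-c1ccccc1` is not yet measured. It differs from compound 2 in one place: fluoro in place of bromo on an aromatic carbon, sitting on an aromatic carbon of a six-membered aromatic ring of carbon only, para to a large group. Going by the values given here, no measured step exchanges bromo for fluoro at that place, and compound 3 changes two things at once against compound 2, so nothing here tells how big such a step is. Among the compounds with values here, with no step bearing on the change, the expectation in this assay is a step of about no change at the digits printed from compound 2 to compound 4 (within the scatter), none beyond the scatter. Compound 4 is therefore estimated at 69%, within a range from 45% to 90%.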

Compound 4, a percentage reported as activity, at one concentration (the size of the read-out at that concentration, not a potency): 55.5%
Beside the measured number, compound 4's estimate is 13.5 percentage points above it; measured number inside the range.
By their numbers in this assay, from the lowest: compound 1; then compound 4; then compounds 2 and 3 (each within the scatter of the next).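

The para substituent on this aromatic ring is not a silent place: in this assay the change from 4-bromophenyl to 4-fluorophenyl gives a number 13.5 percentage points lower from compound 2 to compound 4 (beyond the scatter) and so a stronger effect at the concentration tested. For the compounds shown here, until now the only one-place step lay on the sulfur, so this is the first sign that the shared core's aromatic ring can also shift the read-out, even with one halogen atom exchanged for another. Nothing measured here accounts for why this exchange moves the number.

As far as these compounds go, whether the same exchange would have a similar effect with the 1-phenyl-1H-tetrazol-5-yl group of compound 1 on the sulfur remains open. So does what chloro, an amino group or a plain hydrogen would do at this place on the ring.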